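A few compounds are considered here, and "the series" means these few. Any claim that something is new, unique, unknown or untested is made for them only; others in the source may bear on it.

Measured compounds in an assay on CHO cells for displacement of a labelled ligand from Substance-P receptor (Homo sapiens), in the presence of a further agent that is not named here; a higher number here means a weaker inhibitor, a lower number a stronger inhibitor:
compound 1, `C[C@@H](O[C@H]1CN2C(=O)C=C(c3ccc(F)cc3)CC2[C@@H]1c1ccc(F)cc1)c1cc(C(F)(F)F)cc(C(F)(F)F)c1`, 100 nM;
compound 2, `C[C@@H](O[C@H]1CN2C(=O)C=C(c3cnn(C)c3)CC2[C@@H]1c1ccc(F)cc1)c1cc(C(F)(F)F)cc(C(F)(F)F)c1`, 5.4 nM;
compound 3, `C[C@@H](O[C@H]1CN2C(=O)C=C(C3=CCC(O)CC3)CC2[C@@H]1c1ccc(F)cc1)c1cc(C(F)(F)F)cc(C(F)(F)F)c1`, 13 nM.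

Compound 1 gives the highest number of the three and is thus the weakest inhibitor among them. Compound 4, `C[C@@H](O[C@H]1CN2C(=O)C=C(C3CCOCC3)CC2[C@@H]1c1ccc(F)cc1)c1cc(C(F)(F)F)cc(C(F)(F)F)c1`, is not yet measured; it differs from compound 1 in one place: oxan-4-yl in place of 4-fluorophenyl on a double-bonded ring carbon. Two measured steps exchange the same group on compound 1 for another ring. The step of a 19-fold lower number from compound 1 to compound 2 (1.27 log units; beyond the scatter) and the step of a 7.7-fold lower number from compound 1 to compound 3 (0.89 log units; beyond the scatter) both lowered the number well beyond the scatter. A lower number in this assay is therefore expected for compound 4 as well, by a modest step of the kind seen with compound 3 rather than the large one seen with compound 2. The estimate for compound 4 is 15 nM, within 5 nM to 50 nM, which corresponds to an expected step of a 6.7-fold lower number from compound 1 to compound 4 (0.82 log units; beyond the scatter).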

Compound 4, half-maximal inhibitory concentration: 3.2 nM
Compound 4: middle estimate off by 4.7-fold (0.67 log units), on the high side, and the stated range ends above it.
By their numbers in this assay, from the lowest: compounds 4 and 2 (each within the scatter of the next); then compound 3; then compound 1.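

The 4-fluorophenyl group can give way to a ring that is not aromatic and still produce a large drop, a 31-fold lower number from compound 1 to compound 4 (1.49 log units; beyond the scatter), so an aromatic ring is not needed here for a low number. Non-aromatic rings are not interchangeable at this carbon, as a 4.1-fold lower number from compound 3 to compound 4 (0.61 log units; beyond the scatter) shows, while oxan-4-yl and 1-methyl-1H-pyrazol-4-yl cannot be told apart, with a 1.7-fold lower number from compound 2 to compound 4 (0.23 log units; within the scatter). No supporting measurement explains these differences.

Going by these compounds, what a plain cyclohexyl ring, or a piperidin-4-yl ring with an amine in place of the ring oxygen, would do at this carbon stays open.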